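Trifluoromethyl to Nitro on an Aromatic Ring

The source may hold more compounds than are shown below. What is called first, only, known or untested is meant among the compounds shown, and "the series" means these compounds.

In a functional assay on CEM-SS cells (Homo sapiens) for cytotoxicity (on this read-out lower numbers stand for stronger inhibition and higher numbers for weaker inhibition), compound 1 `Nc1nc2cc(Cl)c(Cl)cc2n1Cc1ccc([N+](=O)[O-])cc1` gives 32000 nM as a true reading. Compound 2 `FC(F)(F)c1ccc(Cn2c(Br)nc3cc(Cl)c(Cl)cc32)cc1` reads > 100000 nM here, and this is a limit of the assay, not a number. Compound 2 therefore has no exact place on the scale.

Compound 3 `O=[N+]([O-])c1ccc(Cn2c(Br)nc3cc(Cl)c(Cl)cc32)cc1` has not yet been measured. It carries nitro in place of trifluoromethyl on an aromatic carbon, para to a large group (nitro in place of trifluoromethyl on an aromatic carbon) when set against compound 2. Among the measured compounds shown here, no two measured compounds differ in one place, so no measured step sets the size of this change. For the measured compounds named here, the only guide is compound 1 at 32000 nM as the one true number so far. A modest move toward stronger inhibition is therefore expected in this assay with a real chance that the reading stays at the limit. The estimated step of an at least 1.6-fold lower number from compound 2 to compound 3 (0.22 log units; that floor lies within the scatter) is expected to be small. Compound 3 is expected at about 60000 nM with an estimated span from 20000 nM to 100000 nM as its likely range.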

Compound 3, half-maximal inhibitory concentration: > 100000 nM
Compound 3: only a limit was reported; the forecaster's own chance of this, stated with the estimate: 40%; middle value at least 1.6-fold (0.22 log units) away from the limit.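

In this assay, compound 3 reads > 100000 nM, which is a limit of the assay and not a number, so placing nitro in place of trifluoromethyl did not bring this bromo compound onto the measurable scale. The step between compound 2 and compound 3 cannot be read, since both ends are limits: the limit of > 100000 nM in this assay, at which 2 of the 3 values shown sit. Among the compounds shown here, the one readable change is bromo in place of amino on an aromatic carbon with the nitro kept, and it gives an at least 3.1-fold higher number from compound 1 to compound 3 (0.49 log units; beyond the scatter).

On these data alone, how far the two bromo compounds lie past the limit stays open, so nitro and trifluoromethyl cannot be ranked against each other here. Also open, as far as these compounds go, is whether a methyl group or a hydroxyl group on the carbon that carries the bromo would give a true reading, as the amino group does.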